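The source may report more compounds than this note shows. Statements on the series, on what has been measured and on what is new or still open speak of the compounds shown alone.

Measured so far:
- compound 1, `NC(=O)c1c(NC(=O)c2ccccc2Cl)sc2c1CCN(Cc1ccc(Cl)cc1Cl)C2`: 21100 nM
- compound 2, `NC(=O)c1c(NC(=O)c2ccccc2Cl)sc2c1CCN(C(=S)Nc1ccccc1F)C2`: 28700 nM

Of the compounds shown here, two sharing one core have been measured in a functional assay on HeLa cells (Homo sapiens) for antiproliferative activity, with a stated time of 24 h; on this read-out higher numbers stand for weaker inhibition and lower numbers for stronger inhibition. Going by the values given here, compound 2 stands beside compound 1, the only other measured compound, and the two are not separated: a 1.4-fold higher number from compound 1 to compound 2 (0.13 log units; within the scatter). That single step swapped the group on the amine nitrogen in the ring and left the numbers essentially where they were.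

Compound 3, `COc1ccc(NC(=S)N2CCc3c(sc(NC(=O)c4ccccc4Cl)c3C(N)=O)C2)cc1`, has not yet been measured. It departs from compound 2 at a different place: 4-methoxyphenyl in place of 2-fluorophenyl on an amide-type nitrogen. Among the compounds with values here, no measured step touches this nitrogen or its aryl group, so the only guide is the general behaviour of the series, where the one recorded change, a 1.4-fold higher number from compound 1 to compound 2 (0.13 log units; within the scatter), stayed within the scatter. With nothing pointing in either direction, a shift beyond the scatter is not expected from compound 2 to compound 3, and a 1.1-fold lower number from compound 2 to compound 3 (0.04 log units; within the scatter) is the estimate of that step. Compound 3 is therefore expected to give about 26000 nM in this assay, with a range from 9000 nM to 80000 nM.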

Compound 3, half-maximal inhibitory concentration: 36400 nM
The estimate for compound 3 lay 1.4-fold (0.15 log units) below the measured number; the range from low to high includes it.
By their numbers in this assay, from the lowest: compounds 1, 2 and 3 (each within the scatter of the next).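

In this assay, going by these compounds alone, 4-methoxyphenyl in place of 2-fluorophenyl on the amide-type nitrogen gives a 1.3-fold higher number from compound 2 to compound 3 (0.10 log units; within the scatter), so the first step at this position does not separate the two aryl groups, even though the entering group carries a hydrogen-bond acceptor and an oxygen where the leaving group carries no acceptor and a fluorine. The wider change on the amine nitrogen in the ring gives a 1.7-fold higher number from compound 1 to compound 3 (0.24 log units; within the scatter), which also stays within the scatter, so compound 3 is not told apart from compound 1 or compound 2 and all three groups on that nitrogen remain equivalent in this assay. Nothing available explains why these exchanges leave the number in place.

Still open, from the compounds shown here alone, is whether an amine or a carboxylic acid on this aryl ring, or a longer alkyl chain in place of the ring, would move the number beyond the scatter at this position. Also open, going by these compounds, is whether a change to the shared core itself, such as a nitrile in place of its primary amide, would do so.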